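Working notes: bromo to nitro on the aromatic ring

A few compounds are considered here, and "the series" means these few. Any claim that something is new, unique, unknown or untested is made for them only; others in the source may bear on it.

Values from a functional assay on MOLT-4 cells (Homo sapiens) for cytotoxicity, read by CCK-8 assay, with a stated time of 24 h (a higher number here means a weaker inhibitor, a lower number a stronger inhibitor), follow
compound 1 `C=CC(=O)N1C(=O)CC(c2ccc(C)cc2)Sc2ccccc21` gives 87600 nM
compound 2 `C=CC(=O)N1C(=O)CC(c2ccc(Br)cc2)Sc2ccccc21` gives 106000 nM
compound 3 `C=CC(=O)N1C(=O)CCSc2ccccc21` gives 565000 nM

Compound 2 stands within the scatter of compound 1 and clear of compound 3 (a 5.3-fold higher number from compound 2 to compound 3 (0.73 log units; beyond the scatter)). The next case is compound 4 `C=CC(=O)N1C(=O)CC(c2ccc([N+](=O)[O-])cc2)Sc2ccccc21`, still unmeasured. Its change from compound 2 is nitro in place of bromo on an aromatic carbon and reads in words as nitro in place of bromo on an aromatic carbon, para to a large group.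

Going by the values given here, the one measured exchange at this place (a 1.2-fold higher number from compound 1 to compound 2 (0.08 log units; within the scatter)) stayed within the scatter. The two modest steps (a 6.4-fold higher number from compound 1 to compound 3 (0.81 log units; beyond the scatter) and a 5.3-fold higher number from compound 2 to compound 3 (0.73 log units; beyond the scatter)) came with hydrogen in place of the whole 4-methylphenyl or 4-bromophenyl group, and compound 4 keeps its substituted ring. Those two steps therefore offer little guide to this exchange. Among the compounds with values here, no measured compound carries a nitro group, and a single exchange is thin evidence, so the range is kept wide.

No shift beyond the scatter is expected in this assay, and the estimated step is a 1.1-fold lower number from compound 2 to compound 4 (0.05 log units; within the scatter) in either direction at most a small one. Compound 4 is expected at 95000 nM (range 42000 nM to 210000 nM).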

Compound 4, half-maximal inhibitory concentration: 91500 nM
For compound 4 the middle estimate is 1.0-fold (0.02 log units) above the measured one, within the range that was stated.
By their numbers in this assay, from the lowest: compounds 1, 4 and 2 (each within the scatter of the next); then compound 3.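

Read in this assay nitro in place of bromo on an aromatic carbon, para to a large group, gives a 1.2-fold lower number from compound 2 to compound 4 (0.06 log units; within the scatter) and nitro in place of methyl gives a 1.0-fold higher number from compound 1 to compound 4 (0.02 log units; within the scatter) and both steps lie within the scatter. Going by these compounds alone, the single earlier exchange at this place now becomes a set of three: compound 1, compound 2 and compound 4 cannot be told apart in this read-out, although they carry methyl, bromo and nitro. The entering nitro brings more heavy atoms than bromo and two hydrogen-bond acceptors where bromo has none, yet no shift beyond the scatter accompanies that exchange, and nothing available offers an explanation for this lack of change.

Going by these compounds, whether an amine, a carboxylic acid or a longer chain at this place would also stay within the scatter remains open, as does the outcome of any of these groups elsewhere on the same aromatic ring. The contribution of the acryloyl group also remains open, as every compound shown carries it.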